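The source may hold more compounds than are shown below. What is called first, only, known or untested is meant among the compounds shown, and "the series" means these compounds.

Compound 2 `COc1ccc2ncc(S(=O)(=O)c3cccc(Cl)c3)c(N3CCC(C)CC3)c2c1` gives -3% in an assay on isolated protein for displacement of a labelled ligand from metabotropic glutamate receptor 5 (Homo sapiens), with a stated time of 60 min, tested at 1 uM (on this read-out higher numbers stand for more inhibition at the one concentration tested (going by the name of the read-out) and lower numbers for less inhibition), the lower of the two numbers recorded, with compound 1 `COc1ccc2ncc(S(=O)(=O)c3ccc(C)c(Cl)c3)c(N3CCC(C)CC3)c2c1` as its nearest neighbour at 85%. Among the compounds with values here, the only measured step, a number 88 percentage points lower from compound 1 to compound 2 (beyond the scatter), shows that this single change was large and beyond the scatter. Compound 3 `COc1ccc2ncc(S(=O)(=O)c3cc(F)cc(F)c3)c(N3CCC(C)CC3)c2c1` has not yet been measured; it differs from compound 2 by 3,5-difluorophenyl in place of 3-chlorophenyl on a sulfonyl sulfur. Within the data shown here, no measured step touches this exchange of one halogenated phenyl for another: the single step known concerns the loss of the methyl group, and it tells nothing about what fluorine in place of chlorine would do on the sulfonyl sulfur. Since both compound 2 and compound 3 lack the methyl whose removal produced the collapse, compound 3 is expected to stay near compound 2, with a step of a number 8 percentage points higher from compound 2 to compound 3 (within the scatter) that is estimated to remain within the scatter. The estimate for compound 3 is 5%, with a range from -15% to 35%.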

Compound 3, a percentage reported as inhibition, at one concentration (the size of the read-out at that concentration, not a potency): 30%
Compound 3: middle estimate off by 25 percentage points, on the low side, and the stated range covers the measured number.
By their numbers in this assay, from the lowest: compound 2; then compound 3; then compound 1.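

In this assay, 3,5-difluorophenyl in place of 3-chlorophenyl on the sulfonyl sulfur gives a number 33 percentage points higher from compound 2 to compound 3 (beyond the scatter), so the read-out at this position can recover in part without any methyl on the aryl group. Recovery remains incomplete, since 3,5-difluorophenyl in place of 3-chloro-4-methylphenyl gives a number 55 percentage points lower from compound 1 to compound 3 (beyond the scatter), and the methyl-bearing group of compound 1 stays ahead of the difluorinated one. No supporting data bear on why either exchange shifts the number as it does.

From the compounds shown here alone, the exchange in compound 3 swaps the kind of halogen and changes the number of halogens at once, so it remains open whether a 3-fluorophenyl group alone would account for the gain. Also open, going by these compounds, is whether an ethyl or methoxy group could stand in for the methyl of compound 1 and hold the read-out.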